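A few compounds are considered here, and "the series" means these few. Any claim that something is new, unique, unknown or untested is made for them only; others in the source may bear on it.

Measured in a functional assay (trachea) with Cavia porcellus as the target; a higher number here means a weaker inhibitor, a lower number a stronger inhibitor:
- compound 1 `Oc1nnc(-c2cccnc2)c2ccccc12` gives 10200 nM
- compound 2 `CCCn1nc(-c2cccnc2)c2ccccc2c1=O` gives 3160 nM
- compound 3 `CCCCn1nc(-c2cccnc2)c2ccccc2c1=O` gives 2290 nM

Compound 3 sits at the low end of these numbers. It is level within the scatter with compound 2 and lies clearly under compound 1 at 10200 nM.

Compound 4 `O=c1c2ccccc2c(-c2cccnc2)nn1Cc1cccc(Cl)c1` differs from compound 3 by 3-chlorophenyl in place of propyl on a saturated chain carbon bound to an aromatic nitrogen.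

Among the measured compounds shown here, only one measured step bears on this change, and only loosely: a 1.4-fold lower number from compound 2 to compound 3 (0.14 log units; within the scatter). That step adds a single methyl on the same chain and stays within the scatter, so it says little about a change as large as this one. For the measured compounds named here, no measured compound carries a ring at this place, so the direction rests on thin evidence. The one firm signal is the gap between compound 1 at 10200 nM and compound 3 at 2290 nM, which lies beyond the scatter.

A modest further fall in this assay is therefore expected, with a wide margin. The expected change is a 1.8-fold lower number from compound 3 to compound 4 (0.25 log units; within the scatter). Compound 4 is estimated at 1300 nM, with an expected range from 350 nM to 5000 nM.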

Compound 4, half-maximal inhibitory concentration: 4170 nM
The estimate for compound 4 lay 3.2-fold (0.51 log units) below the measured number; the measured number falls inside the stated range.
By their numbers in this assay, from the lowest: compounds 3, 2 and 4 (each within the scatter of the next); then compound 1.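

In this assay, propyl to 3-chlorophenyl reads as a 1.8-fold higher number from compound 3 to compound 4 (0.26 log units; within the scatter) and ethyl to 3-chlorophenyl reads as a 1.3-fold higher number from compound 2 to compound 4 (0.12 log units; within the scatter) on the saturated chain carbon bound to an aromatic nitrogen. This is the first compound shown with a ring at this place, and the six-membered aromatic ring of carbon only, with its chlorine, leaves the number level within the scatter with both chain compounds. Within these three compounds, then, the place accepts butyl and 3-chlorobenzyl alike, and going from a chain to a ring gives no firm change in either direction.

On these data alone, it remains open whether a tertiary amine or a carboxylic acid on this chain would move the number in this assay beyond the scatter, and whether plain benzyl without the chlorine would read the same as compound 4. The compounds shown also leave open whether a longer chain, such as hexyl, would stay level with compound 3. Nothing on hand gives a reason for the level numbers at this place.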